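Replacing Phenyl with 4-Hydroxybutyl on the Shared Core

This account rests on a few compounds, and the source may have more. Where it says the series, first, only, none or still open, it means among the compounds named here.

Compound 1 `CSc1nc(NCCCc2ccccc2)c2ccccc2n1` in a functional assay on CCRF-CEM cells (Homo sapiens) for cytotoxicity, read by MTT assay, with a stated time of 72 h (a higher number here means that more compound is tolerated, a lower number that less compound is tolerated), gives > 100000 nM, a limit of the assay.
Compound 2 `CSc1nc(NCCCCc2ccccc2)c2ccccc2n1` in this assay gives > 100000 nM, a limit.
Compound 3 `CSc1nc(NCc2ccccc2)c2ccccc2n1` in this assay gives > 100000 nM, a limit.

Compound 3 therefore stands only at a limit, as do the other two measured compounds: the limit of > 100000 nM in this assay, at which 3 of the 3 values shown sit. Going by the values given here, the one step between measured compounds, a step that the two limits leave unreadable from compound 1 to compound 2, is not readable in size because both ends are limits. Compound 4 `CSc1nc(NCCCCCO)c2ccccc2n1` differs from compound 3 by 4-hydroxybutyl in place of phenyl on a saturated chain carbon bound to a nitrogen on an aromatic ring. Among the compounds with values here, no measured step with a readable size bears on this change; all that is known is the shared limit (the limit of > 100000 nM in this assay, at which 3 of the 3 values shown sit). Compound 4 is estimated at 100000 nM, with a range from 30000 nM to 300000 nM, most likely again reported as a limit. The step of a number no higher from compound 3 to compound 4 (the limit leaves the size open) is thus expected to be none beyond the scatter.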

Compound 4, concentration lethal to 50% of the cells: > 100000 nM
Compound 4 gave a limit, no number; the forecaster's own chance of this, stated with the estimate: 80%; the middle value lies on the limit itself.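

Compound 4 stands at a limit in this assay, as do compound 1, compound 2 and compound 3, so no step from any of them to compound 4 can be read: the limit of > 100000 nM in this assay, at which 4 of the 4 values shown sit.

The compounds shown leave open what lethal concentration any of the four would reach in a reading that is not a limit, and so whether the side chain on the shared core matters.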